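The compounds below may be only part of what the source reports. "The series", "measured", "known", "first", "only" and "open" are said of these compounds alone.

Measured in a functional assay on A2780 cells (Homo sapiens) for cytotoxicity, read by MTT assay, with a stated time of 24 h; on this read-out higher numbers stand for weaker inhibition and lower numbers for stronger inhibition:
compound 1 `CCCCC[C@H](CCC[C@@H]1CC=CC(=O)O1)OC` gives 14400 nM
compound 2 `CCCCC[C@H](C[C@@H](O)C[C@H]1CC=CC(=O)O1)OC` gives 28900 nM
compound 3 `CCCCC[C@@H](C[C@@H](O)C[C@H]1CC=CC(=O)O1)OC` gives 33700 nM

Compound 3 has the highest number of the three. Compound 2 sits within the scatter of it, while compound 1 lies beyond the scatter on the lower side. Compound 4 `CCCCC[C@@H](C[C@H](O)C[C@H]1CC=CC(=O)O1)OC` shares all atoms and bonds with compound 3; the change is the two compounds have the same atoms and bonds and differ only in configuration as drawn: 1 of 3 stereo elements differ; a stereocentre at a saturated chain carbon is drawn R in compound 3 and S in compound 4. Going by the values given here, the one measured step that bears on a change of this kind is a 1.2-fold higher number from compound 2 to compound 3 (0.07 log units; within the scatter), relevant through (the fact that compounds 2 and 3 differ only in the configuration as drawn). That step stayed within the scatter, so the expected step is a 1.1-fold lower number from compound 3 to compound 4 (0.04 log units; within the scatter) in this assay, with no movement beyond the scatter. Compound 4 is therefore estimated at 31000 nM, expected to fall between 15000 nM and 65000 nM.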

Compound 4, half-maximal inhibitory concentration: 53700 nM
Compound 4: the middle estimate sits 1.7-fold (0.24 log units) below what was measured; the range from low to high includes it.
By their numbers in this assay, from the lowest: compounds 1, 2, 3 and 4 (each within the scatter of the next, the first and the last beyond it).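

Going by these compounds alone, this second change of configuration, at a different saturated chain carbon from the one that separates compound 2 and compound 3, also stays small in this assay: a 1.6-fold higher number from compound 3 to compound 4 (0.20 log units; within the scatter). With two stereocentres drawn differently, the step is a 1.9-fold higher number from compound 2 to compound 4 (0.27 log units; within the scatter), which still does not exceed the usual variation between repeated measurements. Neither centre has therefore yet shown a clear effect of configuration on this read-out.

Still open, from the compounds shown here alone, is whether an amine or a carboxylic acid in place of the hydroxyl would move the number beyond that variation.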